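Cytotoxicity of a piperidine-bearing acetamide analogue

The source may hold more compounds than are shown below. What is called first, only, known or untested is meant among the compounds shown, and "the series" means these compounds.

Compound 1 `CC(=O)Nc1ccc(-c2nc3cc(C(F)(F)F)ccc3n2C)cc1` sits in a small group examined in an ADME assay on MT4 cells (Homo sapiens) for cytotoxicity, read by MTT assay, with a stated time of 96 h (a higher number here means that more compound is tolerated, a lower number that less compound is tolerated), where compound 1 gives 15000 nM, the lowest of three numbers. Compound 2 `CC(=O)Nc1ccc(-c2nc3cc(C(F)(F)F)ccc3n2C2CCCCC2)cc1` gives 24000 nM and compound 3 `CC(=O)Nc1ccc(-c2nc3cc(C(F)(F)F)ccc3[nH]2)cc1` gives 19000 nM; the step of a 1.6-fold higher number from compound 1 to compound 2 (0.20 log units; within the scatter), the step of a 1.3-fold higher number from compound 1 to compound 3 (0.10 log units; within the scatter) and the step of a 1.3-fold lower number from compound 2 to compound 3 (0.10 log units; within the scatter) all lie within the scatter. Compound 4 `Cn1c(-c2ccc(NC(=O)CN3CCCCC3)cc2)nc2cc(C(F)(F)F)ccc21` differs from compound 1 by piperidin-1-yl in place of hydrogen on a saturated chain carbon bound to a carbonyl carbon. Among the compounds with values here, no measured step touches the acetamido end of the molecule; the three known steps concern only the aromatic nitrogen and none moved this assay beyond the scatter. The expectation is therefore a step of a 1.1-fold higher number from compound 1 to compound 4 (0.03 log units; within the scatter) that stays within the scatter. Compound 4 is estimated at 16000 nM, within 6000 nM to 45000 nM.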

Compound 4, half-maximal cytotoxic concentration: 9000 nM
Compound 4: middle estimate off by 1.8-fold (0.25 log units), on the high side; the range from low to high includes it.
By their numbers in this assay, from the lowest: compounds 4, 1, 3 and 2 (each within the scatter of the next, the first and the last beyond it).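

Within the data shown here, the earlier compounds changed only the aromatic nitrogen, whereas compound 4 gives the first measured step at the acetamido end. In this assay, piperidin-1-yl in place of hydrogen on the saturated chain carbon gives a 1.7-fold lower number from compound 1 to compound 4 (0.22 log units; within the scatter). Even this larger change therefore stays within the scatter, although nothing shown bears on why.

Going by these compounds, whether an open-chain amine, a carboxylic acid or a longer chain on this carbon would also stay within the scatter remains open. So does the effect of piperidin-1-yl when cyclohexyl or hydrogen sits on the aromatic nitrogen.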